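This account rests on a few compounds, and the source may have more. Where it says the series, first, only, none or still open, it means among the compounds named here.

Working notes on the series. In a toxicity assay on MDCK cells (Canis lupus familiaris) for cytotoxicity, read by crystal violet staining, with a stated time of 48 h (a higher number here means that more compound is tolerated, a lower number that less compound is tolerated), compound 1 `Cc1ccc2cc(CN(Cc3ccc(C(C)(C)C)cc3)CC3CCCCC3)c(=O)[nH]c2c1` gives only the limit > 10000 nM. Compound 2 `Cc1ccc2[nH]c(=O)c(CN(Cc3ccc(OCC(=O)OC(C)(C)C)cc3)Cc3ccc(C(C)(C)C)cc3)cc2c1` likewise reaches only the limit > 10000 nM in this assay. Compound 3 `COc1ccc(CN(Cc2ccc(C(C)(C)C)cc2)Cc2cc3cc(C)ccc3[nH]c2=O)cc1` also stops at the limit > 10000 nM in this assay. Where compound 3 stands is thus known only as a limit, and the step that the two limits leave unreadable from compound 2 to compound 3 cannot be sized because of the limit of > 10000 nM in this assay, at which 3 of the 3 values shown sit.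

Compound 4 `Cc1ccc2[nH]c(=O)c(CN(Cc3ccc(OC(F)(F)F)cc3)Cc3ccc(C(C)(C)C)cc3)cc2c1` differs from compound 3 by trifluoromethyl in place of methyl on an oxygen on an aromatic ring. Among the measured compounds shown here, no measured step changes this group; the only step in the set at this position is the unreadable one from the tert-butoxycarbonyl series, and with every value sitting at the limit (the limit of > 10000 nM in this assay, at which 3 of the 3 values shown sit) no size of any step in this assay can be read from the data. The step that the limit leaves unreadable from compound 3 to compound 4 is therefore expected to be no larger than the scatter, with the result most likely again reported as a limit. Compound 4 is estimated at 15000 nM in this assay, with a range from 5000 nM to 50000 nM.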

Compound 4, half-maximal cytotoxic concentration: > 5000 nM
Compound 4 ended at the assay's limit (the forecaster's own chance of this, stated with the estimate: 85%); the middle value does not contradict the limit.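

Among the compounds shown here, no step among compound 2, compound 3 and compound 4 can be read in this assay, since compound 4 also gives only a limit, > 5000 nM. The compounds shown leave open where any half-maximal cytotoxic concentration lies, and whether trifluoromethyl in place of methyl alters it.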